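The compounds below may be only part of what the source reports. "The series", "measured", "known", "first", "only" and "open" are said of these compounds alone.

Compound 1 `O=S(=O)(Nc1cccc2c(Cl)c[nH]c12)c1ccc(Cl)cc1`: 4.3 ug/mL
Compound 2 `N#Cc1ccc(S(=O)(=O)Nc2cccc3c(Cl)c[nH]c23)cc1`: 1.4 ug/mL
Compound 3 `Nc1ccc(S(=O)(=O)Nc2cccc3c(Cl)c[nH]c23)cc1`: 0.81 ug/mL

In a functional assay on P388 cells (Mus musculus) for antiproliferative activity, read by colorimetric assay and MTT assay (a higher number here means a weaker inhibitor, a lower number a stronger inhibitor), compound 3 gives the lowest of the three numbers, though compound 2 lies within the scatter of it, a 1.7-fold lower number from compound 2 to compound 3 (0.24 log units; within the scatter), while compound 1 stands further off, a 5.3-fold lower number from compound 1 to compound 3 (0.72 log units; beyond the scatter). Compound 4 `Nc1ccc(S(=O)(=O)Nc2ccc(F)c3c(Cl)c[nH]c23)cc1` differs from compound 3 by fluoro in place of hydrogen on an aromatic carbon, on the shared core. Within the data shown here, every measured step changes instead the group on the other ring, as in a 3.1-fold lower number from compound 1 to compound 2 (0.49 log units; beyond the scatter); none touches the core, so no measured step bears directly on this change. The expectation is therefore a step not beyond the scatter, a 1.0-fold lower number from compound 3 to compound 4 (0.01 log units; within the scatter). Compound 4 is estimated at 0.8 ug/mL, with a range from 0.3 ug/mL to 2.2 ug/mL.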

Compound 4, half-maximal inhibitory concentration: 0.51 ug/mL
Compound 4: middle estimate off by 1.6-fold (0.20 log units), on the high side; low and high end bracket the measured number.
By their numbers in this assay, from the lowest: compounds 4, 3 and 2 (each within the scatter of the next, the first and the last beyond it); then compound 1.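

In this assay, fluoro in place of hydrogen is the first change shown on the shared core rather than on the other ring, and it gives a 1.6-fold lower number from compound 3 to compound 4 (0.20 log units; within the scatter). This position, para to a large group, therefore takes fluoro with the numbers of compound 3 and compound 4 remaining within the scatter of each other. Nothing measured here offers an explanation for this result. The compounds shown leave open whether a bromo or methoxy group at this position would also stay within the scatter. They also leave open whether fluoro would do the same with the chloro of compound 1 or the cyano of compound 2 on the other ring.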